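This account rests on a few compounds, and the source may have more. Where it says the series, first, only, none or still open, it means among the compounds named here.

Measured compounds in a functional assay on A549 cells (Homo sapiens) for cytotoxicity, read by MTT assay, with a stated time of 72 h; on this read-out higher numbers stand for weaker inhibition and lower numbers for stronger inhibition:
Compound 1 `Cc1cc(=O)n(-c2ccccc2OC(F)(F)F)nc1C(=O)Nc1ccc(Oc2ncnc3c2ccn3C)c(F)c1` gives > 60000 nM, a limit of the assay and not a number.
Compound 2 `Cc1ccc(-n2nc(C(=O)Nc3ccc(Oc4ncnc5c4ccn5C)c(F)c3)c(C)cc2=O)cc1` gives > 60000 nM, likewise a limit of the assay.

Going by the values given here, compound 2 therefore stands only at a limit, not at a number, and the one further value in the set is a limit as well, so that the limit of > 60000 nM in this assay, at which 2 of the 2 values shown sit, covers everything measured. Among the compounds with values here, the single measured step, a step that the two limits leave unreadable from compound 1 to compound 2, runs between two limits, and its size cannot be read. Compound 3 `Cc1cc(=O)n(-c2ccccc2Cl)nc1C(=O)Nc1ccc(Oc2ncnc3c2ccn3C)c(F)c1` is not yet measured. It differs from compound 2 by 2-chlorophenyl in place of 4-methylphenyl on an aromatic nitrogen. Within the data shown here, no measured step with a readable size bears on this change. The only point of reference is that compound 1, which carries 2-(trifluoromethoxy)phenyl on the aromatic nitrogen, also sits at the limit with > 60000 nM. Given that every value shown is a limit, the expectation for compound 3 in this assay is a further limit rather than a number, and the estimate corresponds to a step that the limit leaves unreadable from compound 2 to compound 3. Compound 3 is thus estimated at 80000 nM, with an expected range from 20000 nM to 300000 nM.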

Compound 3, half-maximal inhibitory concentration: > 60000 nM
Compound 3: a limit, no number; the forecaster's own chance of this, stated with the estimate: 75%; the middle value is on the limit's open side.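

No new step can be read: in this assay compound 3 gives > 60000 nM as a limit and not a number, so its steps from compound 1 and from compound 2 cannot be read. The compounds shown leave open whether any group on the aromatic nitrogen yields a number rather than a limit on this read-out.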